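A few compounds are considered here, and "the series" means these few. Any claim that something is new, unique, unknown or untested is made for them only; others in the source may bear on it.

Measured compounds:

Compound 1 `O=C(c1ccc(Cl)cc1)c1ccn(-c2ccc3c(c2)B(O)OC3)c1`. In an ADME assay on L929 cells (Mus musculus) for cytotoxicity, read by resazurin assay, with a stated time of 72 h (a lower number here means a stronger inhibitor, a higher number a weaker inhibitor), compound 1 gives > 10 ug/mL, which is a limit of the assay.
Compound 2 `O=C(c1cccc(Cl)c1)c1ccn(-c2ccc3c(c2)B(O)OC3)c1`. In this assay compound 2 gives > 10 ug/mL, again a limit.
Compound 3 `Cc1ccccc1C(=O)c1ccn(-c2ccc3c(c2)B(O)OC3)c1`. In this assay compound 3 gives > 10 ug/mL, also a limit.

Compound 3 therefore stands at the same limit as the other two, with no number attached; all three values sit at the limit of > 10 ug/mL in this assay, at which 3 of the 3 values shown sit.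

The step to compound 4 `COc1ccc(C(=O)c2ccn(-c3ccc4c(c3)B(O)OC4)c2)cc1` is 4-methoxyphenyl in place of 2-methylphenyl on a carbonyl carbon. The measured steps that bear on it are those among the three aryl ketones on the shared core: a step that the two limits leave unreadable from compound 1 to compound 2, a step that the two limits leave unreadable from compound 1 to compound 3 and a step that the two limits leave unreadable from compound 2 to compound 3. None of them gives a readable size, so no direction beyond the scatter can be drawn from them. Compound 3 shows a limit, and the comparators with a chloro substituent show limits as well, so the change to a 4-methoxyphenyl is expected to leave the read-out at or near that limit.

Compound 4 is expected in this assay at 20 ug/mL, with a range from 8 ug/mL to 60 ug/mL. The expected step is a step that the limit leaves unreadable from compound 3 to compound 4, not distinguishable from no change.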

Compound 4, half-maximal inhibitory concentration: > 10 ug/mL
Compound 4 gave a limit, no number (the forecaster's own chance of this, stated with the estimate: 85%); the middle value lies beyond the limit too.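

No step involving compound 4 can be read against compound 1, compound 2 or compound 3, since all four compounds stand at one limit: the limit of > 10 ug/mL in this assay, at which 4 of the 4 values shown sit.

From the compounds shown here alone, how far each compound lies beyond that limit in this assay, and whether these aryl ketones differ at all, remains open.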